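Removal of the phenol hydroxy in the aminothiazole hydroxamate series

The compounds below may be only part of what the source reports. "The series", "measured", "known", "first", "only" and "open" are said of these compounds alone.

Measured so far:
- compound 1 `O=C(CCCCCCNC(=O)C(O)(O)C(F)(F)F)Nc1ncc(-c2ccc(Br)cc2)s1`: 10000 nM
- compound 2 `O=C(CCCCCCNC(=O)C(O)(O)C(F)(F)F)Nc1ncc(-c2ccc(O)cc2)s1`: 30000 nM

Both values come from an assay on isolated protein for inhibition of histone deacetylase 8 (Homo sapiens), read by chemiluminescence, with a stated time of 3 h; a lower number here means a stronger inhibitor, a higher number a weaker inhibitor. Within the data shown here, compound 2 gives 30000 nM, the higher of the two numbers known; the single step in hand, a 3.0-fold higher number from compound 1 to compound 2 (0.48 log units; beyond the scatter), shows that swapping bromo for hydroxy on the aromatic carbon cost potency by a modest margin that lies beyond the scatter.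

Compound 3 `O=C(CCCCCCNC(=O)C(O)(O)C(F)(F)F)Nc1ncc(-c2ccccc2)s1` is not yet measured. It differs from compound 2 by hydrogen in place of hydroxy on an aromatic carbon. Among the measured compounds shown here, the only step that bears on this change is the one from compound 1 to compound 2, which went the other way in a modest amount; there is no measured pair in which the hydroxy itself is stripped to hydrogen, so the size of the step is uncertain. The expectation is that the unsubstituted phenyl lands between the bromo and hydroxy analogues or close to compound 1, so a modest fall in the number is estimated, a 2.0-fold lower number from compound 2 to compound 3 (0.30 log units; within the scatter). Compound 3 is therefore expected at about 15000 nM, with a range from 5000 nM to 40000 nM in this assay.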

Compound 3, half-maximal inhibitory concentration: 21000 nM
Estimate against measurement, compound 3: 1.4-fold (0.15 log units) below, within the range that was stated.
By their numbers in this assay, from the lowest: compound 1; then compounds 3 and 2 (each within the scatter of the next).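

In this assay, removing the hydroxy from the 4-hydroxyphenyl gives a 1.4-fold lower number from compound 2 to compound 3 (0.15 log units; within the scatter) and so separates hydrogen from hydroxy at this place, para to a large group, by no more than the usual scatter; the phenol hydroxy shows no measurable contribution in either direction. Hydrogen in place of bromo gives a 2.1-fold higher number from compound 1 to compound 3 (0.32 log units; beyond the scatter) and, together with a 3.0-fold higher number from compound 1 to compound 2 (0.48 log units; beyond the scatter), leaves compound 1 as the most potent of the three, with the bromo as the only substituent here set apart from the others, though only by modest steps. Nothing available bears on why the bromo stands apart from hydrogen and hydroxy.

As far as these compounds go, whether this advantage is specific to bromo or is shared by chloro, methyl or methoxy at the same place remains open, as does the outcome with an amine or a carboxylic acid there. From the compounds shown here alone, it is also open whether the same order of bromo, hydrogen and hydroxy would hold with a longer chain in place of the present one, or with the substituent elsewhere on the six-membered ring.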